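A few compounds are considered here, and "the series" means these few. Any claim that something is new, unique, unknown or untested is made for them only; others in the source may bear on it.

Compounds measured in an assay on Cerebral cortex for displacement of a labelled ligand from Adrenergic receptor alpha-1 (Rattus norvegicus); on this read-out lower numbers stand for stronger inhibition and higher numbers for weaker inhibition: compound 1 `Cc1ccc(-c2nn(CCCCN3CCN(c4ccccc4)CC3)c(=O)c3ccccc23)cc1` gives 23.9 nM; compound 2 `COc1ccccc1N1CCN(CCCCn2nc(-c3ccc(C)cc3)c3ccccc3c2=O)CC1` gives 2.6 nM.

Compound 2 stands with the lowest of the two numbers, and its nearest neighbour is compound 1, the step between them being a 9.2-fold lower number from compound 1 to compound 2 (0.96 log units; beyond the scatter). Compound 3 `CCOc1ccccc1N1CCN(CCCCn2nc(-c3ccc(C)cc3)c3ccccc3c2=O)CC1` differs from compound 2 by methyl in place of hydrogen on a saturated chain carbon bound to an oxygen on an aromatic ring. No measured step bears on this change directly; the only shown step concerns the methoxy entering in place of hydrogen, not its extension. In this assay compound 3 is therefore expected to sit close to compound 2, with a step of a 1.5-fold higher number from compound 2 to compound 3 (0.19 log units; within the scatter) that need not pass the scatter. The estimate for compound 3 is 4 nM, ranging from 1.5 nM to 12 nM.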

Compound 3, inhibition constant: 2.23 nM
The estimate for compound 3 lay 1.8-fold (0.25 log units) above the measured number; low and high end bracket the measured number.
By their numbers in this assay, from the lowest: compounds 3 and 2 (each within the scatter of the next); then compound 1.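

Going from 2-methoxyphenyl to 2-ethoxyphenyl in this assay gives a 1.2-fold lower number from compound 2 to compound 3 (0.07 log units; within the scatter), so the added methyl produces no change that can be told from the scatter. Replacing the hydrogen with the whole ethoxy group gives an 11-fold lower number from compound 1 to compound 3 (1.03 log units; beyond the scatter), which shows that the gain seen with methoxy is kept with the longer group. No data are available to explain either step.

On these data alone, whether a longer chain such as propoxy would still keep the number remains open. So does the outcome with a hydroxyl or an amine in this place.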